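From Methoxyphenyl to Bromophenyl on a Shared Core

The source may report more compounds than this note shows. Statements on the series, on what has been measured and on what is new or still open speak of the compounds shown alone.

Of the compounds shown here, two sharing one core have been measured in an ADME assay on NIH3T3 cells (Mus musculus) for cytotoxicity, read by MTT assay; a higher number here means a weaker inhibitor, a lower number a stronger inhibitor. Compound 1 `COc1ccc(-c2c(C#N)c(N)n(/N=C/c3cn(-c4ccccc4)nc3-c3ccccc3)c(=O)c2C#N)cc1` gives 50 ug/mL in this assay, and compound 2 `COc1cc(-c2c(C#N)c(N)n(/N=C/c3cn(-c4ccccc4)nc3-c3ccccc3)c(=O)c2C#N)cc(OC)c1OC` gives 64 ug/mL. For the measured compounds named here, compound 2 stands at the highest of the two numbers, and the single measured step, a 1.3-fold higher number from compound 1 to compound 2 (0.11 log units; within the scatter), lies within the scatter, so the two compounds cannot be ordered.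

Compound 3 `N#Cc1c(-c2ccc(Br)cc2)c(C#N)c(=O)n(/N=C/c2cn(-c3ccccc3)nc2-c2ccccc2)c1N` has not yet been measured in this assay. It differs from compound 2 by 4-bromophenyl in place of 3,4,5-trimethoxyphenyl on an aromatic carbon. Going by the values given here, the only step that bears on this change is a 1.3-fold higher number from compound 1 to compound 2 (0.11 log units; within the scatter), which also exchanged the group on that same aromatic carbon and produced nothing beyond the scatter. Among the compounds with values here, no measured compound carries a bromine, so the direction of any shift is open. The step expected from this change is a 1.2-fold lower number from compound 2 to compound 3 (0.07 log units; within the scatter), nothing beyond the scatter. Compound 3 is therefore estimated at 55 ug/mL, with a range from 25 ug/mL to 120 ug/mL.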

Compound 3, half-maximal inhibitory concentration: > 200 ug/mL
Compound 3 gave a limit, no number; the forecaster's own chance of this, stated with the estimate: 10%; middle value at least 3.6-fold (0.56 log units) away from the limit.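

The position opposite the ring nitrogen proves able to move the result in this assay, which the exchange between the two methoxy-bearing phenyl groups had not shown. 4-Bromophenyl in place of 3,4,5-trimethoxyphenyl gives an at least 3.1-fold higher number from compound 2 to compound 3 (0.49 log units; beyond the scatter), and bromo in place of methoxy gives an at least 4.0-fold higher number from compound 1 to compound 3 (0.60 log units; beyond the scatter), so both steps to the bromine compound lie beyond the scatter and point the same way, towards a weaker inhibitor. The result for compound 3 is a limit of the assay and not a number: the limit of > 200 ug/mL in this assay, at which 1 of the 3 values shown sits.

Going by these compounds, how far either step really reaches therefore stays open. Also open, on these data alone, is what an unsubstituted phenyl or a 4-chlorophenyl would give at this position, so the shift cannot yet be tied to the bromine itself rather than to the departure of the methoxy groups.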